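The source may report more compounds than this note shows. Statements on the series, on what has been measured and on what is new or still open speak of the compounds shown alone.

Working notes on the series in an assay on membranes from liver for displacement of a labelled ligand from Sigma non-opioid intracellular receptor 1 (Rattus norvegicus), read by scintillation counting; a lower number here means a stronger inhibitor, a higher number a weaker inhibitor. Compound 3 `CN(CCCCn1c(=O)oc2ccccc21)Cc1ccc(Cl)cc1` gives 7.1 nM, the lowest of the three numbers; nearest is compound 1 `COc1ccc(CN(C)C(C)CCn2c(=O)oc3ccccc32)cc1` with 21 nM, furthest compound 2 `Cc1ccc(CN(C)CCCCn2c(=O)oc3ccccc32)c(C)c1` with 239 nM. Within the data shown here, the only measured step that changes the aryl group on the saturated chain carbon bound to the amine nitrogen is a 34-fold lower number from compound 2 to compound 3 (1.53 log units; beyond the scatter). Compound 4 `Cc1cccc(CN(C)CCCCn2c(=O)oc3ccccc32)c1` introduces (3-methylphenyl in place of 4-chlorophenyl on a saturated chain carbon bound to an amine nitrogen). Because a 34-fold lower number from compound 2 to compound 3 (1.53 log units; beyond the scatter) was large when 4-chlorophenyl replaced 2,4-dimethylphenyl, moving back from 4-chlorophenyl to a methyl-substituted ring, 3-methylphenyl, is expected to raise the number, though a single methyl need not undo the whole step. Compound 4 is therefore expected to give 45 nM, with a range from 15 nM to 150 nM, an expected step of a 6.3-fold higher number from compound 3 to compound 4 (0.80 log units; beyond the scatter).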

Compound 4, inhibition constant: 102 nM
For compound 4 the middle estimate is 2.3-fold (0.36 log units) below the measured one; the measured number falls inside the stated range.
By their numbers in this assay, from the lowest: compound 3; then compound 1; then compound 4; then compound 2.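

The step to 3-methylphenyl (a 14-fold higher number from compound 3 to compound 4 (1.16 log units; beyond the scatter)) shows that in this assay a single methyl does not keep the low number of 4-chlorophenyl. The second methyl of 2,4-dimethylphenyl still counts for something (a 2.3-fold lower number from compound 2 to compound 4 (0.37 log units; beyond the scatter)), so both methyl-bearing rings stand well above 4-chlorophenyl at this position on the saturated chain carbon bound to an amine nitrogen. Nothing at hand accounts for these differences. The step from compound 3 to compound 4 changes both the substituent and its ring position, so the two remain inseparable. 4-Methylphenyl or 3-chlorophenyl would separate them.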